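The source may hold more compounds than are shown below. What is called first, only, known or untested is meant among the compounds shown, and "the series" means these compounds.

Compounds measured so far in a functional assay on KB cells (Homo sapiens) for antiproliferative activity, read by sulforhodamine B assay, with a stated time of 3 days; on this read-out lower numbers stand for an effect already at smaller amounts and higher numbers for an effect only at larger amounts of compound:

Compound 1, `CCC1=C(O)c2c(oc(-c3ccc(C(F)(F)F)cc3)cc2=O)C(CC)(CC)C1=O`, gives 35.7 uM.
Compound 2, `CCC1=C(O)c2c(oc(-c3ccc(OC)cc3)cc2=O)C(CC)(CC)C1=O`, gives 17.7 uM.
Compound 3, `CCC1=C(O)c2c(oc(-c3ccccc3C(F)(F)F)cc2=O)C(CC)(CC)C1=O`, gives 45.6 uM.

Compound 1 and compound 2 share one core and differ by methoxy in place of trifluoromethyl on an aromatic carbon; this change gave a 2.0-fold lower number from compound 1 to compound 2 (0.30 log units; within the scatter). Compound 3 contains the same atoms as compound 1 joined differently; the difference between the two cores is not broken down here. The number for compound 3 lies within the usual scatter of that for compound 1 but beyond it from that for compound 2.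

Compound 4, `CCC1=C(O)c2c(oc(-c3ccccc3OC)cc2=O)C(CC)(CC)C1=O`, is not yet measured. It relates to compound 3 by methoxy in place of trifluoromethyl on an aromatic carbon. This is the same kind of change as from compound 1 to compound 2, yet in compound 4 the methoxy sits ortho to a large group, whereas in compound 2 it sits para to a large group. For compound 4 a step of similar size is expected, a 1.8-fold lower number from compound 3 to compound 4 (0.26 log units; within the scatter), because the same change elsewhere gave a 2.0-fold lower number from compound 1 to compound 2 (0.30 log units; within the scatter). Compound 4 is therefore estimated at 25 uM, probably between 12 uM and 50 uM.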

Compound 4, concentration for half-maximal effect: 40.8 uM
Compound 4: middle estimate off by 1.6-fold (0.21 log units), on the low side, and the stated range covers the measured number.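

In this assay, methoxy in place of trifluoromethyl gave a 1.1-fold lower number from compound 3 to compound 4 (0.05 log units; within the scatter), while 2-methoxyphenyl in place of 4-methoxyphenyl gave a 2.3-fold higher number from compound 2 to compound 4 (0.36 log units; beyond the scatter). The methoxy-for-trifluoromethyl swap can be compared across the two cores, and the two steps do not differ: the same change on two cores in this assay, a 2.0-fold lower number (0.30 log units; within the scatter) from compound 1 to compound 2 and a 1.1-fold lower number (0.05 log units; within the scatter) from compound 3 to compound 4, 1.8-fold (0.26 log units) apart, within the scatter of two such steps This agrees with the swap carrying over between these two cores, but two pairs cannot show that it holds across the series, and neither step on its own lies beyond the scatter.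

The compounds shown leave open how an amine or a carboxylic acid on the aromatic ring would compare with methoxy. They also leave open whether the swap would behave the same way on a core carrying a longer chain.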